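The source may hold more compounds than are shown below. What is called first, only, known or untested is meant among the compounds shown, and "the series" means these compounds.

Measured compounds:
compound 1 `Cc1cc(C(=O)Nc2ccc(F)cc2)nn1Cc1cc(Cl)ccc1OCc1ccccc1`, in an assay on CHO-K1 cells for displacement of a labelled ligand from prostaglandin E2 receptor EP1 subtype (Homo sapiens) (on this read-out lower numbers stand for stronger inhibition and higher numbers for weaker inhibition), compound 1 gives 79.4 nM
compound 2 `Cc1cc(NC(=O)CC(C)(C)C)nn1Cc1cc(Cl)ccc1OCc1ccccc1`, in this assay compound 2 gives 10 nM
compound 3 `Cc1cc(NC(=O)OCc2ccccc2)nn1Cc1cc(Cl)ccc1OCc1ccccc1`, in this assay compound 3 gives 79.4 nM

Compound 3 stands level with compound 1, the two together at the high end of the three numbers; the gap to compound 2 is the only one that matters, a 7.9-fold higher number from compound 2 to compound 3 (0.90 log units; beyond the scatter), and no change at the digits printed from compound 1 to compound 3 (within the scatter). The next compound, compound 4 `Cc1cc(NC(=O)O[C@H]2CCOC2)nn1Cc1cc(Cl)ccc1OCc1ccccc1`, keeps the carbamate of compound 3 and changes only the group on its oxygen: oxolan-3-yl in place of benzyl on an oxygen next to a carbonyl group. Among the measured compounds shown here, the one measured step that touches this carbonyl carbon is a 7.9-fold higher number from compound 2 to compound 3 (0.90 log units; beyond the scatter); it shows that an aliphatic group there can beat a benzyl group, though neopentyl sits on the carbonyl carbon itself and oxolan-3-yl sits on the oxygen. The other step at this part of the molecule, a 7.9-fold lower number from compound 1 to compound 2 (0.90 log units; beyond the scatter), also favours the aliphatic group, while no change at the digits printed from compound 1 to compound 3 (within the scatter) shows the benzyl carbamate gaining nothing. A move in the same direction as compound 2, but smaller, is therefore expected for compound 4 in this assay, namely a 1.8-fold lower number from compound 3 to compound 4 (0.25 log units; within the scatter). Compound 4 is estimated at 45 nM, with a range from 15 nM to 200 nM.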

Compound 4, half-maximal inhibitory concentration: 79.4 nM
The estimate for compound 4 lay 1.8-fold (0.25 log units) below the measured number, and the stated range covers the measured number.
By their numbers in this assay, from the lowest: compound 2; then compounds 1, 3 and 4 (each within the scatter of the next).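

In this assay, oxolan-3-yl in place of benzyl on the oxygen next to a carbonyl group gave no shift (no change at the digits printed from compound 3 to compound 4 (within the scatter)), so the carbamate tolerates a five-membered non-aromatic ring with one oxygen as readily as an aromatic ring, and the defined stereocentre brings no visible gain. The carbamate also stays level with the (4-fluorophenyl)carbamoyl compound (no change at the digits printed from compound 1 to compound 4 (within the scatter)), while the neopentyl amide keeps its edge (a 7.9-fold higher number from compound 2 to compound 4 (0.90 log units; beyond the scatter)), so two different carbamate groups now fall short of it by the same margin. Nothing measured alongside these numbers explains them.

As far as these compounds go, whether the opposite stereoisomer of the oxolan-3-yl carbamate or a tert-butyl carbamate would read differently remains open. From the compounds shown here alone, it is also open whether the edge of the neopentyl amide survives with oxolan-3-yl placed directly on the carbonyl carbon, or with a terminal amine on that chain.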